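This account rests on a few compounds, and the source may have more. Where it says the series, first, only, none or still open, it means among the compounds named here.

Measured so far in an ADME assay on microsomes from liver (Mus musculus) for metabolic stability, read by LC-MS, with NADPH named in the record, with a stated time of 60 min, tested at 1 uM, in the absence of a further agent (a higher number here means that more of the compound is left, a lower number that less of the compound is left), and both reported as limits:
Compound 1 `COc1ccc(-c2c(C)nc3c(N4CC[C@@H](NS(=O)(=O)C5CC5)C4)cc(C)nn23)cc1OC` gives > 95% as a limit.
Compound 2 `COc1ccc(-c2c(C)nc3c(N4CC[C@@H](NS(=O)(=O)c5ccc(C)cc5)C4)cc(C)nn23)cc1OC` gives > 95% as a limit.

Neither figure is a true number, and the evidence so far is simply the limit of > 95% in this assay, at which 2 of the 2 values shown sit, with nothing finer to read. Compound 3 `COc1ccc(-c2c(C)nc3c(N4CC[C@@H](NS(=O)(=O)c5ccc(NC(C)=O)cc5)C4)cc(C)nn23)cc1OC` differs from compound 2 in one place acetamido in place of methyl on an aromatic carbon on an aromatic carbon: acetamido in place of methyl, para to a large group. Going by the values given here, the only measured step on this part of the molecule is a step that the two limits leave unreadable from compound 1 to compound 2 with 4-methylphenyl in place of cyclopropyl on a sulfonyl sulfur, and it has no readable size. It therefore offers no direction for this assay here, so no step beyond the scatter is expected. The estimated change is a number at least 3 percentage points lower from compound 2 to compound 3 (that floor lies within the scatter) and it remains only an expectation. For compound 3 the expected value is 92% within an estimated range from 75% to 100% for now.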

Compound 3, percent of the compound remaining: > 95%
Compound 3: no number, only a limit; the forecaster's own chance of this, stated with the estimate: 60%; middle value at least 3 percentage points from the limit.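

Compound 3 gives only a limit, as do compound 1 and compound 2, so no step among these three compounds can be read: the limit of > 95% in this assay, at which 3 of the 3 values shown sit. The compounds shown leave open whether cyclopropyl, 4-methylphenyl and 4-acetamidophenyl on the sulfonyl sulfur differ at all in this assay.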